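Compound 2 to compound 3: hydrogen replaces nitro

The source may hold more compounds than are shown below. What is called first, only, known or untested is meant among the compounds shown, and "the series" means these compounds.

Measured in a functional assay, read by spectrophotometry, with a stated time of 2 h (on this read-out lower numbers stand for stronger inhibition and higher numbers for weaker inhibition), so far
- compound 1 `COC(=O)C1=C(C)NC(=O)NC1c1ccc(O)cc1` gives 3.14 ug/mL 
- compound 2 `COC(=O)C1=C(C)NC(=O)NC1c1cccc([N+](=O)[O-])c1` gives 27.1 ug/mL 

Compound 2 at 27.1 ug/mL holds the higher of the two numbers, and its gap to compound 1 lies beyond the scatter. Compound 3 `COC(=O)C1=C(C)NC(=O)NC1c1ccccc1` has hydrogen in place of nitro on an aromatic carbon. Among the compounds with values here, no measured pair shows this change, so the expectation in this assay rests on little: a small move toward lower numbers, not clearly beyond the scatter. The estimated 1.8-fold lower number from compound 2 to compound 3 (0.26 log units; within the scatter) stays modest. Compound 3 is expected at 15 ug/mL within a range from 5 ug/mL to 45 ug/mL on this estimate.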

Compound 3, half-maximal inhibitory concentration: 28.4 ug/mL
The estimate for compound 3 lay 1.9-fold (0.28 log units) below the measured number; measured number inside the range.
By their numbers in this assay, from the lowest: compound 1; then compounds 2 and 3 (each within the scatter of the next).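

In this assay hydrogen in place of nitro on an aromatic carbon gives a 1.0-fold higher number from compound 2 to compound 3 (0.02 log units; within the scatter) so, at this place, meta to a large group, nitro and hydrogen cannot be told apart. Hydrogen in place of hydroxy on an aromatic carbon gives a 9.0-fold higher number from compound 1 to compound 3 (0.96 log units; beyond the scatter) so this is the change in the series that separates compounds, with compound 1 holding the stronger inhibition. No measurement on hand explains either step.

Going by these compounds, whether an amine or a carboxylic acid on the aromatic carbon that carries nitro would stay level with compound 3 remains open. Also open, on these data alone, is whether hydroxy on that same carbon would match compound 1.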